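The compounds below may be only part of what the source reports. "The series", "measured", "known", "first", "only" and "open" are said of these compounds alone.

Of the compounds shown here, three of one series have been measured in an ADME assay on cells (Hepatocyte, Mus musculus) for metabolic stability, with a stated time of 30 min; on this read-out higher numbers stand for a more stable compound and lower numbers for a less stable compound. Compound 1, `O=C(OC1CCC(CN2CCN(c3cc(=O)c4cc(C(F)(F)F)cc([N+](=O)[O-])c4s3)CC2)CC1)c1ccco1`, gives 0.6%. Compound 2, `CS(=O)(=O)NC1CCC(CN2CCN(c3cc(=O)c4cc(C(F)(F)F)cc([N+](=O)[O-])c4s3)CC2)CC1`, gives 111%. Compound 3, `O=C(OC1CCC(CN2CCN(c3cc(=O)c4cc(C(F)(F)F)cc([N+](=O)[O-])c4s3)CC2)CC1)c1ccc(F)cc1`, gives 1.5%. Compound 3 thus stands second highest of the three: its nearest neighbour is compound 1, at a gap that is within the scatter, and its furthest is compound 2, far higher. The steps of a number 110.4 percentage points higher from compound 1 to compound 2 (beyond the scatter) and a number 109.5 percentage points lower from compound 2 to compound 3 (beyond the scatter) show how much a methanesulfonamido group on the saturated ring carbon changes the read-out, while a number 0.9 percentage points higher from compound 1 to compound 3 (within the scatter) shows that exchanging the ring on the carbonyl carbon left the number unchanged within the scatter.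

Compound 4, `O=C(OC1CCC(CN2CCN(c3cc(=O)c4cc(C(F)(F)F)cc([N+](=O)[O-])c4s3)CC2)CC1)c1ccncc1`, differs from compound 3 only on that carbonyl carbon: pyridin-4-yl in place of 4-fluorophenyl on a carbonyl carbon. Going by the values given here, the one measured step that bears on this place, from compound 1 to compound 3, was within the scatter, so no step beyond the scatter is expected for a number 0.5 percentage points higher from compound 3 to compound 4 (within the scatter). Compound 4 is therefore estimated at 2%, within a range from 0.3% to 12%.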

Compound 4, percent of the compound remaining: 1.4%
Compound 4: the middle estimate sits 0.6 percentage points above what was measured, and the stated range covers the measured number.
By their numbers in this assay, from the lowest: compounds 1, 4 and 3 (each within the scatter of the next); then compound 2.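

Set on the carbonyl carbon, pyridin-4-yl brings a ring with a hetero atom and a hydrogen-bond acceptor, which 4-fluorophenyl lacks, yet the change gave a number 0.1 percentage points lower from compound 3 to compound 4 (within the scatter) and, against furan-2-yl, a number 0.8 percentage points higher from compound 1 to compound 4 (within the scatter) in this assay. All three rings at this place therefore stand within the scatter of one another, while ((pyridin-4-yl)carbonyl)oxy in place of methanesulfonamido on the saturated ring carbon gave a number 109.6 percentage points lower from compound 2 to compound 4 (beyond the scatter) and so repeats the large gap seen with the other two carbonyl compounds. Nothing at hand explains these numbers.

Open, as far as these compounds go, is whether a simple alkyl chain on the carbonyl carbon, or an amide nitrogen in place of the oxygen next to the carbonyl group, would bring the number closer to that of compound 2. Open too, from the compounds shown here alone, is whether a plain amine on the saturated ring carbon would read like methanesulfonamido.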